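Methylation of the indole nitrogen in two chalcone series

The compounds below may be only part of what the source reports. "The series", "measured", "known", "first", "only" and "open" are said of these compounds alone.

Measured so far:
Compound 1, `COc1cc(C(=O)/C=C/c2c[nH]c3ccccc23)cc([N+](=O)[O-])c1OC`, gives 1280 nM.
Compound 2, `COc1cc(C(=O)/C(C)=C/c2c[nH]c3ccccc23)cc([Se]C)c1OC`, gives 25 nM.
Compound 3, `COc1cc(C(=O)/C=C/c2cn(C)c3ccccc23)cc([N+](=O)[O-])c1OC`, gives 1890 nM.

These values come from a functional assay on A2780 cells (Homo sapiens) for antiproliferative activity, read by MTT assay, with a stated time of 48 h; a lower number here means a stronger inhibitor, a higher number a weaker inhibitor. Compound 3 arises from compound 1 by methyl in place of hydrogen on an aromatic nitrogen, and this change made a step of a 1.5-fold higher number from compound 1 to compound 3 (0.17 log units; within the scatter). Compound 2 stands apart from compound 1 on a different core; the difference between the two cores is not broken down here. Compound 4, `COc1cc(C(=O)/C(C)=C/c2cn(C)c3ccccc23)cc([Se]C)c1OC`, is not yet measured and arises from compound 2 by methyl in place of hydrogen on an aromatic nitrogen, the same change as that from compound 1 to compound 3. Because the earlier step was a 1.5-fold higher number from compound 1 to compound 3 (0.17 log units; within the scatter), the step for compound 4 is expected to be about as small, a 1.4-fold higher number from compound 2 to compound 4 (0.15 log units; within the scatter). On this basis compound 4 is estimated at 35 nM in this assay, with a likely range from 15 nM to 90 nM.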

Compound 4, half-maximal inhibitory concentration: 35 nM
The estimate for compound 4 equals the measured number at the digits printed; low and high end bracket the measured number.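

In this assay, methyl in place of hydrogen on the aromatic nitrogen gave a step of a 1.4-fold higher number from compound 2 to compound 4 (0.15 log units; within the scatter). Set beside the earlier step, the change carried over from one core to the other with no difference that can be told apart: the same change on two cores in this assay, a 1.5-fold higher number (0.17 log units; within the scatter) from compound 1 to compound 3 and a 1.4-fold higher number (0.15 log units; within the scatter) from compound 2 to compound 4, 1.1-fold (0.02 log units) apart, within the scatter of two such steps. Within the data shown here, this rests on only two pairs, each with a step within the scatter, so it shows that the change made no clear difference on these two cores, but not that the same would hold on any other core.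

The compounds shown leave open whether an ethyl, a longer chain or a benzyl group on that nitrogen would behave as methyl does. They also leave open what an acetyl group there would do.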